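Replacing the ester-bearing vinyl linker with an oxyacetate ester

The source may hold more compounds than are shown below. What is called first, only, known or untested is meant among the compounds shown, and "the series" means these compounds.

Measured compounds:
- compound 1 `O=C(O)/C=C/c1ccncc1-c1ccc2ccccc2c1`: 102%
- compound 2 `COC(=O)/C=C/c1ccncc1-c1ccc2ccccc2c1`: 102%

In an assay on a protein complex for inhibition of CDK8/Cyclin C (Homo sapiens), with a stated time of 1 h, tested at 10 uM (a lower number here means less inhibition, a higher number more inhibition at the concentration tested (going by the name of the read-out)), compound 1 gives 102%. Compound 2, which differs from compound 1 only by no change at the digits printed from compound 1 to compound 2 (within the scatter), gives 102%. Compound 2 therefore stands level with compound 1 at the digits shown, and both sit at the top of what this read-out can report.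

Compound 3 `COC(=O)COc1ccncc1-c1ccc2ccccc2c1` is the next compound. It differs from compound 2 by (methoxycarbonyl)methoxy in place of 2-(methoxycarbonyl)ethenyl on an aromatic carbon. Within the data shown here, only one measured step exists, the one from compound 1 to compound 2, and it touches the ester end of the chain rather than the part of the linker that is exchanged here, so it gives no direct guide to the present change. With the measured compounds saturating this assay, a step is expected for compound 3 that is a number 22 percentage points lower from compound 2 to compound 3 (beyond the scatter), downward, at most moderately. Compound 3 is thus estimated at 80%, within a range from 40% to 102%.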

Compound 3, a percentage reported as inhibition, at one concentration (the size of the read-out at that concentration, not a potency): 11%
Beside the measured number, compound 3's estimate is 69 percentage points above it; the whole stated range lies above it.
By their numbers in this assay, from the lowest: compound 3; then compounds 1 and 2 (each within the scatter of the next).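

At the position opposite the ring nitrogen, the linker itself matters far more than the end of the chain: in this assay, the exchange of 2-(methoxycarbonyl)ethenyl for (methoxycarbonyl)methoxy gives a number 91 percentage points lower from compound 2 to compound 3 (beyond the scatter), whereas the change at the ester end gave no change at the digits printed from compound 1 to compound 2 (within the scatter). Starting from the acid, the exchange of 2-carboxyethenyl for (methoxycarbonyl)methoxy gives a step of the same size, a number 91 percentage points lower from compound 1 to compound 3 (beyond the scatter). The groups that leave and enter have the same heavy-atom count and neither has a ring, so the loss goes with how the chain is built and not with that count.

Still open, from the compounds shown here alone, is whether a carboxylic acid in place of the methyl ester of compound 3, or a longer chain on the same oxygen, would restore inhibition. Nothing available here explains the drop.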